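This account rests on a few compounds, and the source may have more. Where it says the series, first, only, none or still open, it means among the compounds named here.

Going by the values given here, compound 3 `CCOc1ccc(-n2nncc2CN2C(=O)C3(C(C#N)=C(N)Oc4c(N)cc5nc6ccccc6nc5c43)c3ccccc32)cc1` is the only member of the series with a number in a functional assay on MCF7 cells (Homo sapiens) for antiproliferative activity, read by MTT assay, with a stated time of 48 h; a lower number here means a stronger inhibitor, a higher number a weaker inhibitor: compound 3 gives 26800 nM. Compound 1 `Cc1cccc(-n2nncc2CN2C(=O)C3(C(C#N)=C(N)Oc4c3c3nc5ccccc5nc3c3ccccc43)c3ccccc32)c1` reaches only a limit, > 50000 nM. Compound 2 `Cc1ccc(Cl)cc1-n1nncc1CN1C(=O)C2(C(C#N)=C(N)Oc3c2c2nc4ccccc4nc2c2ccccc32)c2ccccc21` likewise stops at a limit, > 50000 nM. Among the compounds with values here, the single step with both ends measured, a step that the two limits leave unreadable from compound 1 to compound 2, is thus unreadable, and the limit of > 50000 nM in this assay, at which 2 of the 3 values shown sit, is where two of the three results sit. Compound 4 `N#CC1=C(N)Oc2c(N)cc3nc4ccccc4nc3c2C12C(=O)N(Cc1cnnn1-c1ccc(F)c(Cl)c1)c1ccccc12` is drawn from compound 3 by one change, (3-chloro-4-fluorophenyl in place of 4-ethoxyphenyl on an aromatic nitrogen). Within the data shown here, no measured step covers this exchange; compounds 1 and 2, which carry other aryl groups on the same aromatic nitrogen but also differ from compound 3 elsewhere, show only that limit. The step of a 1.5-fold higher number from compound 3 to compound 4 (0.17 log units; within the scatter) is expected to stay within the scatter or drift weaker, since compound 3 gives 26800 nM and nothing measured points to a gain. For compound 4 the estimate is 40000 nM, with a range from 15000 nM to 200000 nM, and a real chance that only a limit is reported.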

Compound 4, half-maximal inhibitory concentration: 17800 nM
Compound 4: middle estimate off by 2.2-fold (0.35 log units), on the high side, and the stated range covers the measured number.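

Going by these compounds alone, the exchange of 4-ethoxyphenyl for 3-chloro-4-fluorophenyl gives the first readable step on this aromatic nitrogen, a 1.5-fold lower number from compound 3 to compound 4 (0.18 log units; within the scatter) in this assay. An aryl group with an ether chain and one with two halogens therefore cannot be told apart at this position in this series. Compounds 1 and 2 carry other aryl groups here but differ from compound 4 elsewhere as well, and the step between them cannot be read, as both values are limits: the limit of > 50000 nM in this assay, at which 2 of the 4 values shown sit.

Open, as far as these compounds go, is whether a benzyl group or a plain alkyl chain in place of the aryl ring, or a carboxylic acid or aminomethyl group on that ring, would move the number beyond the scatter. Also open is what the amino group on the core of compound 3 contributes, as no pair shown differs only there.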